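Nitro in Place of Trifluoromethyl: A Cytotoxicity Comparison

This account rests on a few compounds, and the source may have more. Where it says the series, first, only, none or still open, it means among the compounds named here.

Compound 1 `FC(F)(F)c1cccc(Cn2c(Cl)nc3cc(Cl)c(Cl)cc32)c1` and compound 2 `O=[N+]([O-])c1cccc(Cn2c(Cl)nc3cc(Cl)c(Cl)cc32)c1` share one core and differ in a single substituent: nitro in place of trifluoromethyl on an aromatic carbon. In a functional assay on CEM-SS cells (Homo sapiens) for cytotoxicity (a lower number here means a stronger inhibitor, a higher number a weaker inhibitor), compound 1 gives a value that is a limit of the assay, > 100000 nM. In this assay compound 2 likewise gives only a limit, > 100000 nM. The step that the two limits leave unreadable from compound 1 to compound 2 therefore cannot be sized, because of the limit of > 100000 nM in this assay, at which 3 of the 3 values shown sit.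

Compound 3 `FC(F)(F)c1ccc(Cn2c(Br)nc3cc(Cl)c(Cl)cc32)cc1` carries a different core; the difference between the two cores is not broken down here. In this assay compound 3 also gives only a limit, > 100000 nM. Compound 4 `O=[N+]([O-])c1ccc(Cn2c(Br)nc3cc(Cl)c(Cl)cc32)cc1` has not yet been measured and stands to compound 3 as compound 2 stands to compound 1: nitro in place of trifluoromethyl on an aromatic carbon. The two places are not the same word for word, one substituent sitting meta to a large group and the other para to a large group, so this is the same kind of change rather than the same change.

The step that the limit leaves unreadable from compound 3 to compound 4 in this assay is estimated from the limit at which compound 3 sits, > 100000 nM. Compound 4 is accordingly expected to give 150000 nM in this assay, most probably again only as a limit, with the expected range running from 50000 nM to 600000 nM.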

Compound 4, half-maximal inhibitory concentration: > 100000 nM
Compound 4 ended at the assay's limit (the forecaster's own chance of this, stated with the estimate: 85%); the middle value lies beyond the limit too.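

No step can be read from compound 3 to compound 4, any more than from compound 1 to compound 2, because all four compounds stop at the same limit of this assay: the limit of > 100000 nM in this assay, at which 4 of the 4 values shown sit.

The compounds shown leave open whether nitro in place of trifluoromethyl on an aromatic carbon makes any difference in this assay, and whether that difference would depend on where the group sits.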